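The compounds below may be only part of what the source reports. "The series", "measured", "known", "first", "only" and "open" are said of these compounds alone.

Measured compounds, in a functional assay on HeLa cells (Homo sapiens) for antiproliferative activity, read by MTT assay, with a stated time of 48 h; a higher number here means a weaker inhibitor, a lower number a stronger inhibitor:
- compound 1 `CN1CCN(CCn2c(N)c(-c3nc4ccccc4[nH]3)c3nc(C#N)c(C#N)nc32)CC1` gives > 50000 nM, which is a limit of the assay rather than a number.
- compound 2 `CCN(CC)CCCn1c(N)c(-c2nc3ccccc3[nH]2)c2nc(C#N)c(C#N)nc21` gives 3150 nM.

Among the measured compounds shown here, compound 2 therefore holds the only actual number in this assay; the other value shown is a limit, noted as the limit of > 50000 nM in this assay, at which 1 of the 2 values shown sits. For the measured compounds named here, the step of an at least 15-fold lower number from compound 1 to compound 2 (1.20 log units; beyond the scatter) is the one measured step, and it shows that exchanging the terminal amine on the chain can move the result strongly.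

Compound 3 `N#Cc1nc2c(-c3nc4ccccc4[nH]3)c(N)n(CCCNc3ccccc3)c2nc1C#N` carries the change (anilino in place of diethylamino on a saturated chain carbon, three bonds along the chain from an aromatic nitrogen). Going by the values given here, no measured step covers an anilino group, so the step from compound 1 to compound 2 bears on it only in that it touches the same end of the chain, and it gives no direction for this particular exchange. The expectation is therefore a modest change at most, with wide uncertainty.

Compound 3 is estimated to give 5000 nM, expected between 1500 nM and 20000 nM, which means an expected step of a 1.6-fold higher number from compound 2 to compound 3 (0.20 log units; within the scatter) in this assay.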

Compound 3, half-maximal inhibitory concentration: 26300 nM
Compound 3: middle estimate off by 5.3-fold (0.72 log units), on the low side, and the stated range ends below it.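

In this assay, the step of an 8.3-fold higher number from compound 2 to compound 3 (0.92 log units; beyond the scatter) shows that the end of this chain responds to an anilino group as well as to the 4-methylpiperazin-1-yl group of the earlier comparison. The earlier compounds shown here showed only that diethylamino could be better than one ring-bearing amine, whereas this result adds a second exchange away from diethylamino that also raises the number, and it does so with an aromatic ring and on the 3-(diethylamino)propyl chain itself. The remaining step, an at least 1.9-fold lower number from compound 1 to compound 3 (0.27 log units; that floor lies within the scatter), gives no firm order for that pair, as it starts from a value that is a limit and not a number: the limit of > 50000 nM in this assay, at which 1 of the 3 values shown sits.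

The compounds shown leave open whether the higher number of compound 3 goes with the aromatic ring or with the hydrogen on the nitrogen of the anilino group, a question that a cyclohexylamino group or an anilino group carrying a methyl on that nitrogen could separate. They also leave open how smaller amines such as dimethylamino or pyrrolidin-1-yl, or a longer chain bearing diethylamino, would compare with compound 2.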